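Mirror Image of a Urea: Expectation for Compound 3

A few compounds are considered here, and "the series" means these few. Any claim that something is new, unique, unknown or untested is made for them only; others in the source may bear on it.

Two ureas have been tested in an ADME assay on the whole organism with Oryza sativa as the target, tested at 10 uM; a higher number here means a weaker effect of the compound at the concentration tested, a lower number a stronger effect. Compound 1, `CCCCCCCc1ccc(NC(=O)N[C@@H](C)c2ccccc2)cc1`, gives 99% there. Compound 2, `C[C@@H](NC(=O)Nc1ccc(C(F)(F)F)cc1)c1ccccc1`, gives 82% in this assay, the lower of the two numbers, and its gap to compound 1 lies beyond the usual scatter. Compound 3, `C[C@H](NC(=O)Nc1ccc(C(F)(F)F)cc1)c1ccccc1`, has not yet been measured. It differs from compound 2 only in handedness: the two compounds have the same atoms and bonds and differ only in configuration as drawn: 1 of 1 stereo elements differ; a stereocentre at a saturated chain carbon is drawn R in compound 2 and S in compound 3. Among the compounds with values here, no measured pair shows what such a change does here, so only a small step is expected, if anything slightly upward and within the scatter: a number 6 percentage points higher from compound 2 to compound 3 (within the scatter). Compound 3 is therefore expected to give about 88% in this assay, between 70% and 100%.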

Compound 3, a percentage reported as activity, at one concentration (the size of the read-out at that concentration, not a potency): 94%
The estimate for compound 3 lay 6 percentage points below the measured number, and the stated range covers the measured number.
By their numbers in this assay, from the lowest: compound 2; then compounds 3 and 1 (each within the scatter of the next).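

In this assay, handedness at this saturated chain carbon makes a measurable difference: the change gives a number 12 percentage points higher from compound 2 to compound 3 (beyond the scatter). That step can be traced to the stereocentre alone because nothing else changes: the fact that compounds 2 and 3 differ only in the configuration as drawn. With the configuration of compound 3, trifluoromethyl in place of heptyl on an aromatic carbon gives a number 5 percentage points lower from compound 1 to compound 3 (within the scatter), so the two groups cannot be told apart here. The compounds shown leave open whether the mirror image of compound 1 would show a similar step, and what an amine or a carboxylic acid would do on that aromatic carbon.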